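Cinnamoyl series: acid chloride in place of the hydroxamate

The source may hold more compounds than are shown below. What is called first, only, known or untested is meant among the compounds shown, and "the series" means these compounds.

Compound 1 `CC(=O)ONC(=O)/C=C/c1ccccc1OC(=O)c1ccccc1` gives 21300 nM in a functional assay on HCT-116 cells (Homo sapiens) for inhibition, read by ELISA, with a stated time of 24 h (a lower number here means a stronger inhibitor of growth, a higher number a weaker inhibitor of growth), the highest of the two numbers shown; compound 2 `O=C(/C=C/c1ccccc1OC(=O)c1ccccc1)NOC(=O)c1ccccc1` gives 13600 nM, and the step of a 1.6-fold lower number from compound 1 to compound 2 (0.19 log units; within the scatter) lies within the scatter. Compound 3 `O=C(Cl)/C=C/c1ccccc1OC(=O)c1ccccc1` differs from compound 1 by chloro in place of acetoxyamino on a carbonyl carbon. Going by the values given here, no measured step bears on this change: the only step recorded swaps phenyl for methyl on a carbonyl carbon and stays within the scatter, so it gives no direction. The expected step for compound 3 is a 1.1-fold lower number from compound 1 to compound 3 (0.03 log units; within the scatter), none beyond the scatter, with wide uncertainty. Compound 3 is estimated at 20000 nM, between 5000 nM and 80000 nM.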

Compound 3, concentration for 50% growth inhibition: > 100000 nM
Compound 3: only a limit was reported; the forecaster's own chance of this, stated with the estimate: 10%; middle value at least 5.0-fold (0.69 log units) away from the limit.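

Chloro in place of acetoxyamino on this carbonyl carbon gives the first change in the series that lies beyond the scatter: this assay shows an at least 4.6-fold higher number from compound 1 to compound 3 (0.67 log units; beyond the scatter) for this change. For compound 3 the reading is only a limit: the limit of > 100000 nM in this assay, at which 1 of the 3 values shown sits. Growth inhibition in this pair therefore depends on what sits on the carbonyl carbon.

The compounds shown do not separate the contributions of the nitrogen and the acetyl part of acetoxyamino. As far as these compounds go, whether an amine or a carboxylic acid at this place would keep growth inhibition also remains open.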